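Removing a methyl from compound 2: what to expect

A few compounds are considered here, and "the series" means these few. Any claim that something is new, unique, unknown or untested is made for them only; others in the source may bear on it.

Three compounds share a common core and were tested for their ability to slow the growth of cervical cancer cells in culture in a functional assay on HeLa cells (Homo sapiens) for antiproliferative activity, read by WST assay, with a stated time of 72 h; on this read-out higher numbers stand for weaker inhibition and lower numbers for stronger inhibition. Compound 1, `COC(=O)/C=C/c1ccc(NCc2cc([N+](=O)[O-])ccc2O)cc1`, gives 16000 nM. Compound 2, `COC(=O)/C=C/c1ccc(NCc2cccc(OC)c2O)cc1`, gives 3040 nM. Compound 3, `COC(=O)/C=C/c1ccc(NCc2cc(Cl)cc(Cl)c2O)cc1`, gives 25900 nM. Among these three, compound 2 carries the lowest number, and its gaps to compound 1 and to compound 3 both lie beyond the usual scatter of this assay, so compound 2 is the strongest inhibitor of the set.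

Compound 4, `COC(=O)/C=C/c1ccc(NCc2cccc(O)c2O)cc1`, is not yet measured. Compared with compound 2, the change is this: hydrogen in place of methyl on an oxygen on an aromatic ring. Put differently, the methoxy becomes a hydroxy. Within the data shown here, no directly comparable pair of measured compounds shows what such a change does here, so the expectation rests on the small size of the change alone: a small step, if any, most likely not beyond the scatter, with a slight lean toward a weaker result. Compound 4 is therefore estimated at 4000 nM, with a plausible range from 1500 nM to 12000 nM, which means an expected step of a 1.3-fold higher number from compound 2 to compound 4 (0.12 log units; within the scatter).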

Compound 4, half-maximal inhibitory concentration: 68200 nM
Beside the measured number, compound 4's estimate is 17-fold (1.23 log units) below it, and the stated range ends below it.
By their numbers in this assay, from the lowest: compound 2; then compounds 1 and 3 (each within the scatter of the next); then compound 4.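

Taking away a single methyl, one carbon and nothing more, produces a 22-fold higher number from compound 2 to compound 4 (1.35 log units; beyond the scatter) in this assay, so even the smallest edit at this oxygen on an aromatic ring can weigh heavily on the result. Among these compounds, no two of the earlier compounds differ in only one place, so they could not isolate the effect of any single group, whereas this pair shows that the methoxy and the hydroxy are not interchangeable here, with the methoxy of compound 2 giving the much stronger inhibition. No information is available on why the number moves so far, so the step stands as an observation without an explanation.

Still open, going by these compounds, is whether the methyl itself matters or whether another group on this oxygen would serve as well; an ethyl, giving an ethoxy with a longer chain, or an amine in place of the oxygen would help to separate these possibilities. A cell-growth number on its own also leaves open which stage between adding a compound and slowing cell growth is affected by this change.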